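The compounds below may be only part of what the source reports. "The series", "measured", "known", "first", "only" and "open" are said of these compounds alone.

Notes on the series in an assay for inhibition of Indoleamine 2,3-dioxygenase 1 (Homo sapiens), read by HPLC, with a stated time of 48 h; on this read-out lower numbers stand for stronger inhibition and higher numbers for weaker inhibition. Compound 1 `O=C(NCc1cccc(Cn2cnc3ccccc32)c1)c1cc2cc(O)ccc2[nH]1` gives 781 nM. Compound 2 `O=C(NCc1cccc(Cn2cnc3ccccc32)c1)c1ccc(Br)cc1` gives 134 nM, and the change of 5-hydroxy-1H-indol-2-yl to 4-bromophenyl on the carbonyl carbon reads a 5.8-fold lower number from compound 1 to compound 2 (0.77 log units; beyond the scatter). Compound 3 `O=C(NCc1cccc(Cn2cnc3ccccc32)c1)c1ccc(Cl)cc1` gives 477 nM; against compound 1 the step is a 1.6-fold lower number from compound 1 to compound 3 (0.21 log units; within the scatter), so these two cannot be separated, while the halogen exchange gives a 3.6-fold higher number from compound 2 to compound 3 (0.55 log units; beyond the scatter). Compound 3 thus holds the second highest number of the three, with compound 2 the only one set clearly apart from it.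

Compound 4 `N#Cc1ccc(C(=O)NCc2cccc(Cn3cnc4ccccc43)c2)cc1` differs from compound 3 by cyano in place of chloro on an aromatic carbon, placed on an aromatic carbon of a six-membered aromatic ring of carbon only. For the measured compounds named here, no measured step changes a halogen for a cyano group; the only step at this position, a 3.6-fold higher number from compound 2 to compound 3 (0.55 log units; beyond the scatter), exchanges one halogen for another and gives no direct guide. With nothing to lean on, the expectation for compound 4 is a number near that of compound 3, a step of a 1.0-fold higher number from compound 3 to compound 4 (0.02 log units; within the scatter) that is not expected to exceed the scatter. The estimate for compound 4 is 500 nM, within 150 nM to 1600 nM.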

Compound 4, half-maximal inhibitory concentration: 90 nM
The estimate for compound 4 lay 5.6-fold (0.74 log units) above the measured number, and the stated range ends above it.
By their numbers in this assay, from the lowest: compounds 4 and 2 (each within the scatter of the next); then compounds 3 and 1 (each within the scatter of the next).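

In this assay cyano in place of chloro gives a clear step (a 5.3-fold lower number from compound 3 to compound 4 (0.72 log units; beyond the scatter)), so a group that is not a halogen can reach the low end of this series at the position para to a large group. The step from the bromo compound (a 1.5-fold lower number from compound 2 to compound 4 (0.17 log units; within the scatter)) leaves 4-cyanophenyl and 4-bromophenyl inseparable, while 4-cyanophenyl stands clear of 5-hydroxy-1H-indol-2-yl (an 8.7-fold lower number from compound 1 to compound 4 (0.94 log units; beyond the scatter)). Nothing at hand explains why chloro stands apart from both bromo and cyano.

Open, on these data alone, is how a carboxylic acid, an amine or a methoxy group would read on the same aromatic carbon, and whether iodo would side with bromo or with chloro. Also open, as far as these compounds go, is whether the 4-cyanophenyl result holds when the shared core is changed.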